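The source may report more compounds than this note shows. Statements on the series, on what has been measured and on what is new or still open speak of the compounds shown alone.

Compound 1 `Cc1cc(C)c(CN2CCc3c(Cl)cc([C@@H](CO)[C@@H]4CCOC4)c(Cl)c3C2=O)c(=O)[nH]1` — 25.3 uL/min. Compound 2 `COC(c1cc(Cl)c2c(c1Cl)C(=O)N(Cc1c(C)cc(C)[nH]c1=O)CC2)C1CCOCC1` — 130 uL/min; 129 uL/min (2 entries). Compound 3 `Cc1cc(C)c(CN2CCc3c(Cl)cc([C@@H](C)CO)c(Cl)c3C2=O)c(=O)[nH]1` — 12.4 uL/min.

In an ADME assay on microsomes from liver (Homo sapiens) for metabolic stability, read by LC-MS, using NADPH, with stated times of 10 min and 45 min, tested at 1 uM (on this read-out lower numbers stand for slow clearance and higher numbers for fast clearance), compound 3 gives the lowest of the two single numbers; the nearest is compound 1, reached by reversing a 2.0-fold lower number from compound 1 to compound 3 (0.31 log units; beyond the scatter). Compound 2 has several entries the several entries of compound 2 in this assay, 130 uL/min; 129 uL/min (2 entries) and is not placed by a single number.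

Compound 4 `Cc1cc(C)c(CN2CCc3c(Cl)cc([C@H](CO)[C@@H]4CCCO4)c(Cl)c3C2=O)c(=O)[nH]1` differs from compound 3 in one place:
oxolan-2-yl in place of methyl on a saturated chain carbon bound to an aromatic carbon and a saturated chain carbon

Within the data shown here, the only measured step that bears on this is a 2.0-fold lower number from compound 1 to compound 3 (0.31 log units; beyond the scatter), where a group containing a five-membered non-aromatic ring gave way to a smaller chain. Reversing that direction, a modest rise is expected for compound 4. Compound 4 is therefore estimated at 25 uL/min, with a range from 12 uL/min to 50 uL/min. The expected step is a 2.0-fold higher number from compound 3 to compound 4 (0.30 log units; within the scatter).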

Compound 4, intrinsic clearance in a liver preparation (reported as CLH), per the amount of preparation that the assay uses: 37.6 uL/min
Estimate against measurement, compound 4: 1.5-fold (0.18 log units) below, and the stated range covers the measured number.
By their numbers in this assay, from the lowest: compound 3; then compounds 1 and 4 (each within the scatter of the next).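

At this saturated chain carbon, oxolan-2-yl in place of methyl raises the clearance number in this assay (a 3.0-fold higher number from compound 3 to compound 4 (0.48 log units; beyond the scatter)). The two five-membered ring groups are not told apart (a 1.5-fold higher number from compound 1 to compound 4 (0.17 log units; within the scatter)), and both compounds stand above the methyl compound 3. Nothing measured here gives a cause for the step.

The compounds shown leave open whether the rise follows the ring itself or simply the larger group, which an open chain such as ethyl or methoxymethyl at this carbon could separate. Going by these compounds, how a six-membered oxane ring or an amine would read at this carbon also remains open.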